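Lengthening the chain of compound 3

The source may report more compounds than this note shows. Statements on the series, on what has been measured and on what is new or still open speak of the compounds shown alone.

In a functional assay on FL5.12 cells (Mus musculus) for cytotoxicity, read by flow cytometry, with a stated time of 48 h (on this read-out higher numbers stand for weaker inhibition and lower numbers for stronger inhibition), compound 1 `CCCCCCCCCCCCC/C=C/[C@@H](O)[C@H](CO)N(C)C` gives 800 nM while compound 2 `CCCCCCCCCCCCCCc1ccc(CO[C@@H]2CN[C@@H](CO)C2)cc1` gives 10500 nM and compound 3 `CCCCCCCCCCc1ccc(CO[C@H]2CN[C@H](CO)C2)cc1` gives 3600 nM on the same read-out. Compound 3 thus holds the second highest of the three numbers, and its gaps to both other compounds lie beyond the scatter. Compound 4 `CCCCCCCCCCCCCCc1ccc(CO[C@H]2CN[C@H](CO)C2)cc1` differs from compound 3 by one change, butyl in place of hydrogen on a saturated chain carbon, ten or more bonds along the chain from an aromatic carbon with butyl in place of hydrogen on a saturated chain carbon, ten or more bonds along the chain from an aromatic carbon. Within the data shown here, no measured step shows this change directly. Compound 2, at 10500 nM with the chain of compound 4 but different stereochemistry, points towards a higher number. A modest step towards weaker inhibition is therefore expected, with a 1.4-fold higher number from compound 3 to compound 4 (0.14 log units; within the scatter) as the estimated step in this assay and close to the scatter. The value of compound 4 is estimated at 5000 nM (expected range 1900 nM to 12000 nM).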

Compound 4, half-maximal inhibitory concentration: 5700 nM
Beside the measured number, compound 4's estimate is 1.1-fold (0.06 log units) below it, and the stated range covers the measured number.
By their numbers in this assay, from the lowest: compound 1; then compounds 3, 4 and 2 (each within the scatter of the next, the first and the last beyond it).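

In this assay, butyl in place of hydrogen on a saturated chain carbon, ten or more bonds along the chain from an aromatic carbon, gives a 1.6-fold higher number from compound 3 to compound 4 (0.20 log units; within the scatter), so this chain change is now read directly and does not separate from the scatter. The mirror images at this chain length are not told apart either, with a 1.8-fold lower number from compound 2 to compound 4 (0.27 log units; within the scatter), and this comparison isolates configuration alone: the fact that compounds 2 and 4 differ only in the configuration as drawn

From the compounds shown here alone, whether configuration matters at the shorter chain of compound 3 stays open. So does what a still longer chain, or a carboxylic acid on the shared core, would do in this assay.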